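Trimming One Methoxy From a Weak Urea Cytotoxin

A few compounds are considered here, and "the series" means these few. Any claim that something is new, unique, unknown or untested is made for them only; others in the source may bear on it.

Compound 1, `COc1ccc(CN(C(=O)Nc2ccc(Cl)cc2)n2cnnc2)cc1OC`, gives > 50000 nM in a functional assay on MDA-MB-231 cells (Homo sapiens) for cytotoxicity, read by MTT assay, with a stated time of 48 h (on this read-out higher numbers stand for weaker inhibition and lower numbers for stronger inhibition), which is a limit of the assay and not a number.
Compound 2, `CCc1ccc(NC(=O)N(Cc2cc(OC)c(OC)c(OC)c2)n2cnnc2)cc1`, gives 24800 nM in this assay.

Compound 2 thus holds the only actual number among the two results shown; the other entry is a limit, (the limit of > 50000 nM in this assay, at which 1 of the 2 values shown sits). Both compounds share a urea core joined to a benzyl group and a triazole ring, and both are weak on this read-out.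

Compound 3, `CCc1ccc(NC(=O)N(Cc2ccc(OC)c(OC)c2)n2cnnc2)cc1`, is the next compound awaiting measurement. It is derived from compound 2 by a single change, (hydrogen in place of methoxy on an aromatic carbon), that is, hydrogen in place of methoxy on an aromatic carbon of the six-membered aromatic ring of carbon only, ortho to a methoxy group and meta to a large group.

Within the data shown here, no measured pair shows this particular change, so there is no direct guide to its effect. Given how weak compound 2 already is, the step is expected to be small, a 1.4-fold higher number from compound 2 to compound 3 (0.15 log units; within the scatter), staying within the usual scatter or drifting toward weaker inhibition. Compound 3 is therefore expected at 35000 nM, within a range from 12000 nM to 100000 nM.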

Compound 3, half-maximal inhibitory concentration: > 50000 nM
Compound 3 ended at the assay's limit; the forecaster's own chance of this, stated with the estimate: 40%; at least 1.4-fold (0.15 log units) between middle value and limit.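

Hydrogen in place of methoxy on an aromatic carbon, ortho to a methoxy group and meta to a large group, now has a measured outcome in this assay: the result is an at least 2.0-fold higher number from compound 2 to compound 3 (0.30 log units; that floor lies within the scatter). The reading for compound 3 is a limit of the assay and not a number, so only the floor of this step is known, and that floor alone does not establish a real loss of activity. Compound 2 remains the only compound here with an actual number, while the other two compounds stop at the same edge of the measurable range: the limit of > 50000 nM in this assay, at which 2 of the 3 values shown sit.

The step between compound 1 and compound 3, which puts ethyl in place of chloro on an aromatic carbon, cannot be read, with a limit on each side. Going by these compounds, what an amine, a hydroxyl group or a longer alkoxy chain would do on this aromatic carbon in place of the methoxy stays open, as does whether any group at this position could bring the number well below that of compound 2.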